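Does Losing One Methyl Change Cell Tolerance?

The source may report more compounds than this note shows. Statements on the series, on what has been measured and on what is new or still open speak of the compounds shown alone.

In an ADME assay on cells (Homo sapiens) for cytotoxicity, read by resazurin assay, with a stated time of 5 days (a higher number here means that more compound is tolerated, a lower number that less compound is tolerated), compound 3 `COc1ccc(-c2nc(C(C)S(=O)(=O)c3cccc(Cl)c3)nc3ccsc23)cn1` gives > 50000 nM, which is a limit and not a number. Compound 2 `O=S(=O)(Cc1nc(-c2ccncc2)c2sccc2n1)c1cccc(Cl)c1` gives > 50000 nM, which is also a limit. Compound 1 `COc1ccc(Nc2nc(CS(=O)(=O)c3cccc(Cl)c3)nc3ccsc23)cc1` is the only one of the three with an actual number, at 60000 nM.

Compound 4 `COc1ccc(-c2nc(CS(=O)(=O)c3cccc(Cl)c3)nc3ccsc23)cn1` differs from compound 3 in a single place: hydrogen in place of methyl on a saturated chain carbon bound to an aromatic carbon and a sulfonyl sulfur. That is hydrogen in place of methyl on a saturated chain carbon bound to an aromatic carbon and a sulfonyl sulfur.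

For the measured compounds named here, no measured step covers this change. Going by the values given here, the only one available is a step that the limit leaves unreadable from compound 1 to compound 2, and it concerns a different group, with pyridin-4-yl in place of (4-methoxyphenyl)amino on an aromatic carbon. The best guide is therefore the general level of the series, which is the limit of > 50000 nM in this assay, at which 2 of the 3 values shown sit. No large step is expected in this assay because compound 1 reads 60000 nM and so sits at a similar high level.

The expected change, a number no higher from compound 3 to compound 4 (the limit leaves the size open), is therefore small. For compound 4 the estimated value is 50000 nM, with an expected range from 20000 nM to 100000 nM. The result may well be expected as a limit rather than a number.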

Compound 4, half-maximal cytotoxic concentration: > 10000 nM
Compound 4: only a limit was reported; the forecaster's own chance of this, stated with the estimate: 65%; the middle value is on the limit's open side.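

In this assay compound 4 gives > 10000 nM, which is a limit and not a number. For the compounds shown here, no step can therefore be read from compound 1, compound 2 or compound 3 to compound 4. The compounds shown leave open whether hydrogen in place of methyl changes how much compound the cells tolerate at all.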